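Two Cytotoxicity Limits and an Ether-Extended Side Chain

The compounds below may be only part of what the source reports. "The series", "measured", "known", "first", "only" and "open" are said of these compounds alone.

Compound 1 `CS(=O)(=O)CCCn1c(Cn2cc(S(C)(=O)=O)c3ccncc32)nc2cc(Cl)ccc21`: a limit, > 100000 nM
Compound 2 `CS(=O)(=O)c1nn(Cc2nc3cc(Cl)ccc3n2CCCCO)c2cnccc12`: a limit, > 100000 nM

In an ADME assay on HEp-2 cells (Homo sapiens) for cytotoxicity, with a stated time of 4 days (on this read-out lower numbers stand for higher toxicity in this test and higher numbers for lower toxicity in this test), compound 2 gives only a limit, > 100000 nM. In this assay compound 1 likewise gives a limit, > 100000 nM. Both therefore sit at the limit of > 100000 nM in this assay, at which 2 of the 2 values shown sit, and nothing separates them. Compound 3 `CS(=O)(=O)c1nn(Cc2nc3cc(Cl)ccc3n2CCOCCO)c2cnccc12` is not yet measured; it differs from compound 2 by 2-hydroxyethoxy in place of 2-hydroxyethyl on a saturated chain carbon, two bonds along the chain from an aromatic nitrogen. Among the measured compounds shown here, no measured step between compounds exists here, so no shift beyond the scatter is expected, and a limit is the most likely report. The step that the limit leaves unreadable from compound 2 to compound 3 is estimated to stay within the scatter. Compound 3 is expected at 150000 nM, with a range from 60000 nM to 400000 nM.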

Compound 3, half-maximal cytotoxic concentration: > 100000 nM
Compound 3 was reported as a limit; the forecaster's own chance of this, stated with the estimate: 85%; the middle value is on the limit's open side.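

Compound 2 and compound 3 each give only a limit, so no step between them can be read: the limit of > 100000 nM in this assay, at which 3 of the 3 values shown sit.

The compounds shown leave open what concentration, if any, would reveal toxicity for any of them in this assay.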